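The compounds below may be only part of what the source reports. "The series", "measured", "known", "first", "only" and "open" are said of these compounds alone.

Measured so far:
- compound 1, `C1=C(c2cccnc2)CC2CNCC1C2`: 12 nM
- compound 2, `CC(C)Oc1cncc(C2=CC3CC(C2)CN(C)C3)c1`: 1730 nM

In an in vitro assay on SH-SY5Y cells for displacement of a labelled ligand from Neuronal acetylcholine receptor; alpha3/beta4 (Homo sapiens) (on this read-out lower numbers stand for stronger inhibition and higher numbers for weaker inhibition), compound 2 gives 1730 nM, the higher of the two numbers measured; compound 1 gives 12 nM, and the gap between the two lies beyond the usual scatter. The two compounds differ in more than one place, so no single change can be read from that gap.

Compound 3, `CN1CC2C=C(c3cncc(C#N)c3)CC(C2)C1`, is not yet measured. It differs from compound 2 in one place: cyano in place of isopropoxy on an aromatic carbon.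

Among the compounds with values here, no measured pair shows this change on its own, so its size has to be guessed. Both groups carry one hydrogen-bond acceptor, and the entering group is the smaller one. A moderate move toward a lower number, near the edge of the scatter, is expected for compound 3, a 1.9-fold lower number from compound 2 to compound 3 (0.28 log units; within the scatter). Compound 3 is therefore estimated at 900 nM, with a range from 250 nM to 3500 nM.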

Compound 3, inhibition constant: 4500 nM
The estimate for compound 3 lay 5.0-fold (0.70 log units) below the measured number; the whole stated range lies below it.
By their numbers in this assay, from the lowest: compound 1; then compound 2; then compound 3.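

Cyano in place of isopropoxy on this aromatic carbon gives a 2.6-fold higher number from compound 2 to compound 3 (0.42 log units; beyond the scatter) in this assay, the first change at this position that can be read on its own. The step runs toward weaker inhibition although both groups carry the same count of hydrogen-bond acceptors and neither carries a donor, so in this pair a smaller group at this place does not bring stronger inhibition. No measurement available on this series accounts for the step.

Open, from the compounds shown here alone, is how a methoxy group or a primary amine on the same aromatic carbon would stand against cyano and isopropoxy, since one pair gives no trend with group size. Also open, going by these compounds, is whether either group would read the same on the core of compound 1.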